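Removing the fluorobenzyl group from a sulfonamide piperidine

A few compounds are considered here, and "the series" means these few. Any claim that something is new, unique, unknown or untested is made for them only; others in the source may bear on it.

Compound 1 `Cc1ccc(S(=O)(=O)N2CCC(N3CCC(C)CC3)CC2)cc1C` gives > 5000 nM in an ADME assay on HCT-116 cells (Homo sapiens) for cytotoxicity, read by CellTiter-Glo, with a stated time of 72 h; a higher number here means a weaker inhibitor, a lower number a stronger inhibitor.
Compound 2 `Cc1cc(C)c(S(=O)(=O)N2CCC(N3CCC(Cc4ccc(F)cc4)CC3)CC2)c(C)c1` gives > 5000 nM in this assay.
Compound 3 `Cc1cc(C)c(S(=O)(=O)NC2CCC(N3CCC(C)CC3)CC2)c(C)c1` gives > 5000 nM in this assay.

Each of these three values is a limit of this assay rather than a measured number. For compound 2 the value > 5000 nM is such a limit. The same holds for compound 1 and for compound 3, so compound 2 stands alongside the others with no number to rank it by, as the limit of > 5000 nM in this assay, at which 3 of the 3 values shown sit, records: every value shown sits at that limit.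

Compound 4 `Cc1cc(C)c(S(=O)(=O)N2CCC(N3CCCCC3)CC2)c(C)c1` has not yet been measured in this assay. It differs from compound 2 by hydrogen in place of 4-fluorobenzyl on a saturated ring carbon. Among the compounds with values here, no step between two measured compounds is available, so no measured change can be drawn on. All three compounds, whatever group sits on the saturated ring carbon, stay at the limit, and nothing in the data suggests compound 4 would leave it.

The expected step that the limit leaves unreadable from compound 2 to compound 4 is therefore none beyond the scatter. For compound 4 the estimate in this assay is 10000 nM, with a range from 5000 nM to 30000 nM, most likely reported again as a limit.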

Compound 4, half-maximal inhibitory concentration: > 5000 nM
Compound 4 was reported as a limit; the forecaster's own chance of this, stated with the estimate: 85%; the middle value does not contradict the limit.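

Compound 4 gives > 5000 nM in this assay, which is a limit and not a number. Within the data shown here, compound 2 also sits at a limit, so no step from compound 2 to compound 4 can be read. Still open, on these data alone, is whether the group on the saturated ring carbon changes cytotoxicity at all, since every compound shares one reading: the limit of > 5000 nM in this assay, at which 4 of the 4 values shown sit.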